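Replacing the aryl group of compound 3

A few compounds are considered here, and "the series" means these few. Any claim that something is new, unique, unknown or untested is made for them only; others in the source may bear on it.

In a functional assay on HepG2 cells (Homo sapiens) for antiproliferative activity, read by spectrophotometry, with a stated time of 2 days (on this read-out lower numbers stand for stronger inhibition of growth and higher numbers for weaker inhibition of growth), compound 3 `Cc1cc(Cl)ccc1Nc1ncc(C(F)(F)F)c(N2Cc3cccc(N(C)S(C)(=O)=O)c3C2)n1` gives 19600 nM and stands within the scatter of compound 1 `CN(c1cccc2c1CN(c1nc(Nc3cc(C(F)(F)F)cc(C(F)(F)F)c3)ncc1C(F)(F)F)C2)S(C)(=O)=O` at 10300 nM on the same read-out. Compound 2 `Cc1cc(C)cc(Nc2ncc(C(F)(F)F)c(N3Cc4cccc(N(C)S(C)(=O)=O)c4C3)n2)c1` returned a limit (> 30000 nM) and no number. Compound 4 `COc1cc(Nc2ncc(C(F)(F)F)c(N3Cc4cccc(N(C)S(C)(=O)=O)c4C3)n2)cc(C(F)(F)F)c1` carries 3-methoxy-5-(trifluoromethyl)phenyl in place of 4-chloro-2-methylphenyl on a nitrogen on an aromatic ring. Within the data shown here, the one measured step at this place (an at least 1.5-fold lower number from compound 2 to compound 3 (0.18 log units; that floor lies within the scatter)) has a floor inside the scatter and gives no firm ground for a large move. No shift beyond the scatter is therefore expected in this assay and the estimated step (a 1.3-fold lower number from compound 3 to compound 4 (0.12 log units; within the scatter)) stays small. Compound 4 is estimated at 15000 nM with an expected range from 6000 nM to 30000 nM on this read-out.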

Compound 4, concentration for 50% growth inhibition: 22100 nM
Estimate against measurement, compound 4: 1.5-fold (0.17 log units) below; the range from low to high includes it.
By their numbers in this assay, from the lowest: compounds 1, 3 and 4 (each within the scatter of the next, the first and the last beyond it). At a limit, above all of these: compound 2.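

Exchanging 4-chloro-2-methylphenyl for 3-methoxy-5-(trifluoromethyl)phenyl on this nitrogen leaves the read-out in this assay unmoved, although the entering group carries a hydrogen-bond acceptor: a 1.1-fold higher number from compound 3 to compound 4 (0.05 log units; within the scatter). Among these compounds, the one step here beyond the scatter is methoxy in place of trifluoromethyl on an aromatic carbon: a 2.1-fold higher number from compound 1 to compound 4 (0.33 log units; beyond the scatter). The step of an at least 1.3-fold lower number from compound 2 to compound 4 (0.13 log units; that floor lies within the scatter) rests on a limit and gives only a floor: the limit of > 30000 nM in this assay, at which 1 of the 4 values shown sits.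

Open, on these data alone, is whether an amine or a carboxylic acid on this phenyl group would shift the number beyond the scatter. The compounds shown carry only neutral substituents there, so the reach of this position remains untested.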